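Bridged diamine in place of cyclopropylpiperazine on the core

A few compounds are considered here, and "the series" means these few. Any claim that something is new, unique, unknown or untested is made for them only; others in the source may bear on it.

Compound 1, `CN(C[C@H]1Cc2c(cccc2N2CCN(C3CC3)CC2)CN1)[C@H]1CCCc2cccnc21`: 23.5 nM
Compound 2, `CC(C)N(C[C@H]1Cc2c(cccc2N2CCNCC2)CN1)[C@H]1CCCc2cccnc21`: 364 nM

Among the measured compounds shown here, both were measured in a functional assay on CCRF-CEM cells for antagonist activity at C-X-C chemokine receptor type 4 (Homo sapiens), read by calcium flux, with stated times of 25 min and 90 s; on this read-out higher numbers stand for weaker inhibition and lower numbers for stronger inhibition; compound 1 gives 23.5 nM there, the lowest of the two numbers, while compound 2 differs from it in more than one place and gives a higher number, so no single step is counted between them. Compound 3, `CN(C[C@H]1Cc2c(cccc2N2C[C@H]3C[C@@H]2CN3)CN1)[C@H]1CCCc2cccnc21`, is not yet measured. It differs from compound 1 in one place: a group of 7 heavy atoms (5 carbon, 2 nitrogen; 2 five-membered non-aromatic rings with 1 hetero atom each) in place of a group of 9 heavy atoms (7 carbon, 2 nitrogen; one three-membered non-aromatic ring of carbon only, one six-membered non-aromatic ring with 2 hetero atoms), on an aromatic carbon. For the measured compounds named here, with no counted step to rest on, the expected step is modest, toward a higher number: a 2.6-fold higher number from compound 1 to compound 3 (0.41 log units; beyond the scatter). Compound 3 is therefore expected to give about 60 nM, between 15 nM and 250 nM.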

Compound 3, half-maximal inhibitory concentration: 20.7 nM
For compound 3 the middle estimate is 2.9-fold (0.46 log units) above the measured one, within the range that was stated.
By their numbers in this assay, from the lowest: compounds 3 and 1 (each within the scatter of the next); then compound 2.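

In this assay, the exchange of 4-cyclopropylpiperazin-1-yl for the bridged diamine is a 1.1-fold lower number from compound 1 to compound 3 (0.06 log units; within the scatter), so the two compounds cannot be told apart. At this aromatic carbon, then, a smaller group with two defined stereocentres and one hydrogen-bond donor is accepted, where the group it replaces has no donor. Nothing measured here offers an explanation for this result. The compounds shown leave open whether the mirror-image form of the bridged diamine, a cyclopropyl group on its free amine, or a morpholine at this place would read alike.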